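Furan-3-yl Amide Replaces Methylpyridyl on a Shared Core

A few compounds are considered here, and "the series" means these few. Any claim that something is new, unique, unknown or untested is made for them only; others in the source may bear on it.

In an assay on CHO cells for displacement of a labelled ligand from histamine receptor H3 (Macaca mulatta), read by scintillation counting, with a stated time of 1 h (a higher number here means a weaker inhibitor, a lower number a stronger inhibitor), compound 3 `Cc1cccc(C(=O)Nc2ccc(N3CC[C@H](N4CCC[C@@H]4C)C3)cc2C)n1` gives 1.4 nM, the lowest of the three numbers measured. Compound 1 `Cc1nc(C(=O)Nc2ccc(N3CC[C@H](N4CCC[C@@H]4C)C3)cc2C)co1` gives 4.6 nM and compound 2 `Cc1cc(C(=O)Nc2ccc(N3CC[C@H](N4CCC[C@@H]4C)C3)cc2C)n[nH]1` gives 4.7 nM; the step of a 1.0-fold higher number from compound 1 to compound 2 (0.01 log units; within the scatter) lies within the scatter, whereas a 3.3-fold lower number from compound 1 to compound 3 (0.52 log units; beyond the scatter) and a 3.4-fold lower number from compound 2 to compound 3 (0.53 log units; beyond the scatter) are both modest. Compound 4 `Cc1cc(N2CC[C@H](N3CCC[C@@H]3C)C2)ccc1NC(=O)c1ccoc1` differs from compound 3 by furan-3-yl in place of 6-methylpyridin-2-yl on a carbonyl carbon. Among the compounds with values here, no measured step introduces a furan-3-yl, but the two steps ending at compound 3 show that exchanging a five-membered aromatic ring with one hetero atom for the six-membered aromatic ring with one hetero atom brought a modest gain, and the reverse direction is now taken. A step of similar size toward a higher number, a 4.3-fold higher number from compound 3 to compound 4 (0.63 log units; beyond the scatter), is expected for compound 4. Compound 4 is estimated at 6 nM, with a range from 2 nM to 20 nM around that estimate.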

Compound 4, inhibition constant: 1.8 nM
Compound 4: middle estimate off by 3.3-fold (0.52 log units), on the high side; the whole stated range lies above it.
By their numbers in this assay, from the lowest: compounds 3 and 4 (each within the scatter of the next); then compounds 1 and 2 (each within the scatter of the next).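

In this assay, furan-3-yl in place of 6-methylpyridin-2-yl gives a 1.3-fold higher number from compound 3 to compound 4 (0.11 log units; within the scatter) and so shows that the six-membered ring is not required on this carbonyl carbon. The earlier five-membered rings had suggested otherwise, yet furan-3-yl differs from them by a 2.6-fold lower number from compound 2 to compound 4 (0.42 log units; beyond the scatter) and by a 2.6-fold lower number from compound 1 to compound 4 (0.41 log units; beyond the scatter) so ring size alone does not set the number here. No evidence given here explains these differences. Going by these compounds, what a phenyl ring, or a methyl group added to the furan-3-yl, would give on this carbonyl carbon remains open.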